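The source may report more compounds than this note shows. Statements on the series, on what has been measured and on what is new or still open speak of the compounds shown alone.

Measured so far in a functional assay on NCI-H460 cells (Homo sapiens) for inhibition, read by sulforhodamine B assay, with a stated time of 48 h; a higher number here means a weaker inhibitor of growth, a lower number a stronger inhibitor of growth:
compound 1, `COc1cc(-c2nn(-c3cccc(NC(=O)Nc4cccc(C(F)(F)F)c4)c3)cc2-c2ccncc2)ccc1Cl`, gives 763 nM
compound 2, `COc1cc(-c2nn(-c3cccc(NC(=O)Nc4ccc(Cl)c(C(F)(F)F)c4)c3)cc2-c2ccncc2)ccc1Cl`, gives 1110 nM

Compound 2 gives the highest of the two numbers, yet it sits close to compound 1: the step of a 1.5-fold higher number from compound 1 to compound 2 (0.16 log units; within the scatter) is within the scatter, so the two cannot be ordered. Compound 3, `COc1cc(-c2nn(-c3cccc(NC(=O)c4ccccc4)c3)cc2-c2ccncc2)ccc1Cl`, has not been measured in this assay. It differs from compound 2 by phenyl in place of (4-chloro-3-(trifluoromethyl)phenyl)amino on a carbonyl carbon. For the measured compounds named here, the only measured step, a chloro in place of hydrogen on an aromatic carbon, is far smaller than this change and does not bear on it directly; it shows only that a small change on the ring leaves the number about where it was. Since the amide-type nitrogen and the aryl group attached to it are lost, a higher number is expected for compound 3, with a step of a 3.2-fold higher number from compound 2 to compound 3 (0.50 log units; beyond the scatter). Compound 3 is therefore estimated at 3500 nM, within a range of 900 nM to 14000 nM.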

Compound 3, concentration for 50% growth inhibition: 394 nM
The estimate for compound 3 lay 8.9-fold (0.95 log units) above the measured number, outside the stated range (below it).
By their numbers in this assay, from the lowest: compounds 3, 1 and 2 (each within the scatter of the next, the first and the last beyond it).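

In this assay, putting phenyl in place of (4-chloro-3-(trifluoromethyl)phenyl)amino on a carbonyl carbon gives a 2.8-fold lower number from compound 2 to compound 3 (0.45 log units; beyond the scatter), so this position, where the other neighbour is an amide-type nitrogen, keeps growth inhibition after losing the amino nitrogen, the chloro and the trifluoromethyl group. Against the (3-(trifluoromethyl)phenyl)amino group the same replacement gives a 1.9-fold lower number from compound 1 to compound 3 (0.29 log units; within the scatter), so phenyl and that group cannot be ordered at this position. Nothing available explains why the smaller group does no worse here.

As far as these compounds go, it remains open whether an aromatic ring is needed on the carbonyl carbon at all, or whether a methyl group or a longer alkyl chain would serve there. Also open, from the compounds shown here alone, is how an amine or a carboxylic acid on the phenyl of compound 3 would move the number.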